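Three compounds at one limit; a fourth expected there too

The source may hold more compounds than are shown below. What is called first, only, known or untested is meant among the compounds shown, and "the series" means these compounds.

Compound 1 `CCOC(=O)CCCCCOc1cccc(CN(C(=O)c2ccc(-c3cccc(N(C)C)c3)cc2)C(C)C)c1` gives > 26000 nM in an ADME assay on HEK293 cells (Homo sapiens) for cytotoxicity, read by CellTiter-Glo and resazurin assay, with a stated time of 72 h (a higher number here means that more compound is needed for the effect, a lower number that less compound is needed), which is a limit of the assay rather than a number.
Compound 2 `CCOC(=O)CCCCCOc1cccc(CN(C(=O)c2ccc(-c3ccncc3)cc2)C(C)C)c1` gives > 26000 nM in this assay, again a limit.
Compound 3 `CCOC(=O)CCCCCOc1cccc(CN(C(=O)c2ccc(-c3cc(F)cc(OC)c3)cc2)C(C)C)c1` gives > 26000 nM in this assay, also a limit.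

For the measured compounds named here, compound 3 therefore stands nowhere in particular among the three: every value shown is the same limit, as the limit of > 26000 nM in this assay, at which 3 of the 3 values shown sit, records, and no compound can be placed above or below another. The three measured steps, a step that the two limits leave unreadable from compound 1 to compound 2, a step that the two limits leave unreadable from compound 1 to compound 3 and a step that the two limits leave unreadable from compound 2 to compound 3, are unreadable for this reason, so nothing about their size is known. Compound 4 `CCOC(=O)CCCCCOc1cccc(CN(C(=O)c2ccc(-c3cccc([N+](=O)[O-])c3)cc2)C(C)C)c1` differs from compound 3 by 3-nitrophenyl in place of 3-fluoro-5-methoxyphenyl on an aromatic carbon. The measured steps bear on this change only in that they cover three different groups on the same aromatic carbon, and each left the readout at the limit. No step beyond the scatter is therefore expected in this assay, in either direction. Compound 4 is expected to give about 40000 nM, within 20000 nM to 100000 nM, and most likely to be reported again only as a limit. For compound 4 this corresponds to an expected step that the limit leaves unreadable from compound 3 to compound 4.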

Compound 4, half-maximal effective concentration: > 26000 nM
Compound 4: no number, only a limit (the forecaster's own chance of this, stated with the estimate: 85%); the middle value lies beyond the limit too.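

Compound 4 gives only a limit, not a number, so its steps from compound 1, compound 2 and compound 3 in this assay cannot be read, because all four compounds share one limit: the limit of > 26000 nM in this assay, at which 4 of the 4 values shown sit.

The compounds shown leave open whether these different groups on the aromatic carbon change the concentration needed for the effect.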